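A few compounds are considered here, and "the series" means these few. Any claim that something is new, unique, unknown or untested is made for them only; others in the source may bear on it.

Working notes on the series. Compound 1 `O=C(O)CCC(=O)/C=C/c1cn(-c2ccccc2)nc1-c1ccccc1` gives 13.5% in a functional assay on the whole organism (strain albino) for inhibition, with Rattus norvegicus as the target, read by paw edema, with stated times of 30 min and 2 h, at a dose of 50 mg/kg by the oral route; on this read-out lower numbers stand for less inhibition and higher numbers for more inhibition at the one dose given (going by the name of the read-out). Compound 2 `O=C(O)CCC(=O)/C=C/c1cn(-c2ccccc2)nc1-c1ccc(Cl)cc1`, carrying chloro in place of hydrogen on an aromatic carbon, gives 10.9% in this assay; the step of a number 2.6 percentage points lower from compound 1 to compound 2 (within the scatter) is within the scatter. Compound 2 therefore stands beside compound 1: the two numbers cannot be told apart, and the inhibition in this assay is level between the two.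

Compound 3 `Cc1ccc(-c2nn(-c3ccccc3)cc2/C=C/C(=O)CCC(=O)O)cc1` differs from compound 2 by methyl in place of chloro on an aromatic carbon. Among the compounds with values here, the only measured step that bears on this position is a number 2.6 percentage points lower from compound 1 to compound 2 (within the scatter), which shows that putting chloro onto that aromatic carbon left the read-out within the scatter. Within the data shown here, no measured pair covers methyl at this place, so the exchange of chloro for methyl rests on a single nearby step that itself showed nothing beyond the scatter. A step from compound 2 to compound 3 in this assay of no size beyond the scatter is expected, in no preferred direction, namely a number 1.1 percentage points higher from compound 2 to compound 3 (within the scatter). For compound 3 the estimate in this assay is 12%, with a range from 3% to 22%.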

Compound 3, a percentage reported as inhibition, in the whole organism at one dose (the size of the read-out at that dose, not a potency): 6.25%
Beside the measured number, compound 3's estimate is 5.8 percentage points above it; low and high end bracket the measured number.
By their numbers in this assay, from the lowest: compounds 3, 2 and 1 (each within the scatter of the next).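

The exchange of chloro for methyl on this aromatic carbon stays within the scatter in this assay, a number 4.7 percentage points lower from compound 2 to compound 3 (within the scatter), and methyl in place of hydrogen does the same, a number 7.3 percentage points lower from compound 1 to compound 3 (within the scatter). Compounds 1 and 2 alone showed only that chloro at this place could not be told apart from hydrogen; with compound 3, a second group, built on carbon rather than chlorine, also leaves the read-out level with hydrogen at the one dose given. No order among compounds 1, 2 and 3 can be claimed from these numbers, and no measurement at hand offers an explanation for this level reading.

Still open, as far as these compounds go, is whether a larger or different group at this carbon, such as methoxy, trifluoromethyl or an amine, would move the inhibition beyond the scatter. Also open, from the compounds shown here alone, is whether an ester or an amide in place of the carboxylic acid of the shared core would change the number more than any exchange at this position has so far.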